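The source may report more compounds than this note shows. Statements on the series, on what has been measured and on what is new or still open speak of the compounds shown alone.

Measured so far:
compound 1 `CC1=C(C(=O)OC(C(F)(F)F)C(F)(F)F)C(c2ccsc2)NC(=O)N1` — 8%
compound 2 `CC1=C(C(=O)OC(C(F)(F)F)C(F)(F)F)C(c2ccoc2)NC(=O)N1` — 1%

Both numbers come from an assay on HeLa cells for displacement of a labelled ligand from adenosine receptor A3 (Homo sapiens), read by radioligand binding, with a stated time of 180 min, tested at 1 uM; a higher number here means more inhibition at the concentration tested (going by the name of the read-out), a lower number less inhibition. Among the measured compounds shown here, compound 1 stands first of the two, its only neighbour being compound 2, and the step of a number 7 percentage points lower from compound 1 to compound 2 (within the scatter) is within the scatter, so the two compounds are not told apart; both sit near the bottom of the read-out.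

Compound 3 `CC1=C(C(=O)OCC(F)(F)F)C(c2ccsc2)NC(=O)N1` differs from compound 1 in one place: hydrogen in place of trifluoromethyl on a saturated chain carbon bound to an oxygen next to a carbonyl group and a saturated chain carbon. For the measured compounds named here, no measured step bears on this position. Going by the values given here, the single step measured, from compound 1 to compound 2, concerns the ring on the saturated ring carbon, not the chain on the oxygen next to the carbonyl group, and it was within the scatter. Among the compounds with values here, with compound 1 at 8% and compound 2 at 1%, the series so far shows only low inhibition.

Compound 3 is therefore expected to stay near compound 1, with the step of a number 1 percentage points lower from compound 1 to compound 3 (within the scatter) expected to lie within the scatter. The estimate for compound 3 is 7%, with a range from -6% to 24%.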

Compound 3, a percentage reported as inhibition, at one concentration (the size of the read-out at that concentration, not a potency): 1%
Compound 3: middle estimate off by 6 percentage points, on the high side, and the stated range covers the measured number.
By their numbers in this assay, from the lowest: compounds 2, 3 and 1 (each within the scatter of the next).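

In this assay, hydrogen in place of trifluoromethyl on a saturated chain carbon bound to an oxygen next to a carbonyl group and a saturated chain carbon gives a number 7 percentage points lower from compound 1 to compound 3 (within the scatter). Among the compounds shown here, this is the first reading at this position, and the loss of the 4 heavy atoms of trifluoromethyl does not tell the two compounds apart, so the position joins the ring step in showing no measurable difference. Nothing available explains this outcome or bears on it.

On these data alone, whether an amine, a carboxylic acid or a longer chain on this chain carbon would move the read-out beyond the scatter stays open. Also open, as far as these compounds go, is whether this position matters in a compound with inhibition well away from the bottom of the read-out, where all three compounds sit.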